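Cytotoxicity Limits Across Three Measured Analogues

The source may hold more compounds than are shown below. What is called first, only, known or untested is meant among the compounds shown, and "the series" means these compounds.

Measured compounds:
- compound 1, `Cc1ccc2[nH]c(=O)c(CN(Cc3ccc(OCC(=O)OC(C)(C)C)cc3)Cc3ccc(C(C)(C)C)cc3)cc2c1`: > 10000 nM
- compound 2, `Cc1ccc2[nH]c(=O)c(CN(Cc3ccc(OCC(=O)O)cc3)Cc3ccc(C(C)(C)C)cc3)cc2c1`: > 10000 nM
- compound 3, `Cc1ccc2[nH]c(=O)c(CN(Cc3ccc(C(N)=O)cc3)Cc3ccc(C(C)(C)C)cc3)cc2c1`: > 5000 nM

In a toxicity assay on MDCK cells (Canis lupus familiaris) for cytotoxicity, read by crystal violet staining, with a stated time of 48 h (a lower number here means that less compound is tolerated, a higher number that more compound is tolerated), compound 1 gives > 10000 nM, which is a limit rather than a number. Compound 2 likewise gives > 10000 nM in this assay, again a limit. Compound 3 gives > 5000 nM in this assay, also a limit. Because all three values are limits, the steps a step that the two limits leave unreadable from compound 1 to compound 2, a step that the two limits leave unreadable from compound 1 to compound 3 and a step that the two limits leave unreadable from compound 2 to compound 3 cannot be sized; compound 3 therefore stands where the other two stand, at a limit, with no measured gap to either of them. Two of the three values sit at the limit of > 10000 nM in this assay, at which 2 of the 3 values shown sit, and one at the limit of > 5000 nM in this assay, at which 1 of the 3 values shown sits.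

The unmeasured compound 4, `Cc1ccc2[nH]c(=O)c(CN(Cc3ccc(C(C)(C)C)cc3)C(C)c3ccc(F)cc3)cc2c1`, differs from compound 3 by 1-(4-fluorophenyl)ethyl in place of 4-carbamoylbenzyl on an amine nitrogen. Among the measured compounds shown here, no measured step touches this position in a readable way, so no step in this assay can be drawn on for the size of the change. Given that compound 3 sits at a limit, compound 4 is expected to show a step that the limit leaves unreadable from compound 3 to compound 4 in this assay, that is, no change beyond the scatter that the data could reveal. Compound 4 is therefore estimated at 8000 nM in this assay, with a range from 2000 nM to 30000 nM, and a real chance that only a limit is reported.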

Compound 4, half-maximal cytotoxic concentration: > 33000 nM
Compound 4 ended at the assay's limit; the forecaster's own chance of this, stated with the estimate: 55%; middle value at least 4.1-fold (0.61 log units) away from the limit.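

In this assay compound 4 gives > 33000 nM, which is a limit and not a number. Compound 2 and compound 3 also stand at limits, so the steps joining compound 4 to them cannot be read. The compounds shown leave open where the half-maximal cytotoxic concentration of any of the four lies, and whether changing the group on the amine nitrogen shifts it at all.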